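Benzyl-substituted triazolopyrimidine amines: outlook for compound 4

This account rests on a few compounds, and the source may have more. Where it says the series, first, only, none or still open, it means among the compounds named here.

Compound 3 `O=[N+]([O-])c1cccc(Nc2ncnc3c2nnn3Cc2ccccc2Cl)c1` gives 3300 nM in an assay on cell membranes for binding affinity to adenosine receptor A1 (Bos taurus), read by radioligand binding (on this read-out lower numbers stand for stronger inhibition and higher numbers for weaker inhibition), the highest of the three numbers recorded. Compound 1 `CC1CCCC(Nc2ncnc3c2nnn3Cc2ccccc2Cl)C1` gives 102 nM and compound 2 `O=[N+]([O-])c1cccc(Nc2ncnc3c2nnn3Cc2ccccc2)c1` gives 443 nM; the steps of a 32-fold higher number from compound 1 to compound 3 (1.51 log units; beyond the scatter) and a 7.4-fold higher number from compound 2 to compound 3 (0.87 log units; beyond the scatter) both exceed the scatter. Compound 4 `Nc1ccc(CNc2ncnc3c2nnn3Cc2ccccc2Cl)cc1` carries the change (4-aminobenzyl in place of 3-nitrophenyl on a nitrogen on an aromatic ring). Among the compounds with values here, only the step from compound 1 to compound 3 bears on this nitrogen, and it was large: replacing 3-methylcyclohexyl by 3-nitrophenyl raised the number a 32-fold higher number from compound 1 to compound 3 (1.51 log units; beyond the scatter). A different group on that nitrogen is therefore expected to move the number well beyond the scatter, most plausibly downward, as the step of an 11-fold lower number from compound 3 to compound 4 (1.04 log units; beyond the scatter). Compound 4 is estimated at 300 nM, with a range from 60 nM to 1500 nM.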

Compound 4, inhibition constant: > 1000 nM
Compound 4: no number, only a limit; the forecaster's own chance of this, stated with the estimate: 5%; middle value at least 3.3-fold (0.52 log units) from the limit.
By their numbers in this assay, from the lowest: compound 1; then compound 2; then compound 3.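

Compound 4 carries only a limit of the assay, not a number: the limit of > 1000 nM in this assay, at which 1 of the 4 values shown sits. The step from compound 3 to compound 4 therefore cannot be read, and 4-aminobenzyl and 3-nitrophenyl stay unordered on this nitrogen. Even so, 4-aminobenzyl, like 3-nitrophenyl, gives a higher number than 3-methylcyclohexyl, with an at least 9.8-fold higher number from compound 1 to compound 4 (0.99 log units; beyond the scatter).

Open, on these data alone, is what an unsubstituted benzyl or a plain cyclohexyl would give on this nitrogen. Also open, as far as these compounds go, is whether the amino group on the benzyl contributes to the result at all.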